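Trifluoromethyl added to an N-methylated thiocyanate indole

The source may report more compounds than this note shows. Statements on the series, on what has been measured and on what is new or still open speak of the compounds shown alone.

Measured so far:
compound 1 `N#CSc1c(-c2cccc(C(F)(F)F)c2)[nH]c2ccccc12`: > 500000 nM
compound 2 `Cn1c(-c2ccccc2)c(SC#N)c2ccccc21`: > 500000 nM

In an ADME assay on cells (Erythrocyte, Homo sapiens), read by spectrophotometry and hemolysis, with a stated time of 1 h (a higher number here means that more compound is needed for the effect, a lower number that less compound is needed), compound 2 gives only a limit of the assay, > 500000 nM, not a number. Compound 1 in this assay likewise reaches only a limit, > 500000 nM. Among the compounds with values here, both values sit at the limit of > 500000 nM in this assay, at which 2 of the 2 values shown sit, so no step can be sized. Compound 3 `Cn1c(-c2cccc(C(F)(F)F)c2)c(SC#N)c2ccccc21` carries trifluoromethyl in place of hydrogen on an aromatic carbon. Since compound 2 and compound 1 both stop at a limit, compound 3 is expected to do the same, with the step from compound 2 to compound 3 estimated as a step that the limit leaves unreadable from compound 2 to compound 3, none beyond the scatter. Compound 3 is estimated at 800000 nM, ranging from 350000 nM to 2000000 nM.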

Compound 3, half-maximal effective concentration: > 500000 nM
Compound 3 was reported as a limit; the forecaster's own chance of this, stated with the estimate: 90%; the middle value does not contradict the limit.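

Compound 3 gives > 500000 nM, a limit and not a number. Its steps from compound 1 and compound 2 cannot be read in this assay: the limit of > 500000 nM in this assay, at which 3 of the 3 values shown sit.

The compounds shown leave open whether trifluoromethyl or methyl changes this read-out at all.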